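Swapping the benzyl substituent on a flavanone-triazole series

The source may report more compounds than this note shows. Statements on the series, on what has been measured and on what is new or still open speak of the compounds shown alone.

Two compounds from a series built on a shared core have been measured in a functional assay on RAW264.7 cells (Mus musculus) for inhibition, read by Griess assay, with stated times of 2 h and 24 h; on this read-out lower numbers stand for stronger inhibition and higher numbers for weaker inhibition. Compound 1 `CCn1cc(COc2cc(O)c3c(c2)O[C@H](c2ccc(OC)c(O)c2)C/C3=N\O)nn1` gives 3140 nM in this assay, while compound 2 `COc1ccc([C@@H]2CC(=O)c3c(O)cc(OCc4cn(Cc5cccc(Cl)c5)nn4)cc3O2)cc1O` gives 18200 nM, the highest of the two numbers shown; compound 1 lies a good deal lower, and the gap between them is beyond the usual scatter. Compound 3 `COc1ccc([C@@H]2CC(=O)c3c(O)cc(OCc4cn(Cc5ccc(C)cc5)nn4)cc3O2)cc1O` has not been measured yet. It differs from compound 2 in one place: 4-methylphenyl in place of 3-chlorophenyl on a saturated chain carbon bound to an aromatic nitrogen. Within the data shown here, no pair of measured compounds shows the effect of this change on its own, so the direction of the step is uncertain. Given how close the two groups are in size, the expected step from compound 2 to compound 3 is a 1.1-fold higher number from compound 2 to compound 3 (0.04 log units; within the scatter), that is, no change beyond the scatter. Compound 3 is therefore estimated at 20000 nM, within a range from 8000 nM to 50000 nM.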

Compound 3, half-maximal inhibitory concentration: 16800 nM
The estimate for compound 3 lay 1.2-fold (0.08 log units) above the measured number, and the stated range covers the measured number.
By their numbers in this assay, from the lowest: compound 1; then compounds 3 and 2 (each within the scatter of the next).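

In this assay, among these compounds, the exchange of 3-chlorobenzyl for 4-methylbenzyl gives a 1.1-fold lower number from compound 2 to compound 3 (0.03 log units; within the scatter), which is the first direct reading of a change on this saturated chain carbon bound to an aromatic nitrogen. For this one pair, therefore, a 4-methylphenyl and a 3-chlorophenyl group, each with one six-membered aromatic ring of carbon only, cannot be told apart in this read-out. No supporting measurement bears on this result.

Among the compounds shown here, compound 1 differs from compound 2 and compound 3 in more than one place, so no step to compound 1 can be read. Going by these compounds, whether the read-out would also stay within the scatter with an amine or a carboxylic acid on the phenyl ring, or with a longer chain in place of the benzyl link, remains open.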